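The source may report more compounds than this note shows. Statements on the series, on what has been measured and on what is new or still open speak of the compounds shown alone.

Series notes, an ADME assay on L1210/0 cells (Mus musculus) for cytotoxicity, with a stated time of 48 h; a lower number here means a stronger inhibitor, a higher number a weaker inhibitor:
Compound 1 `O=C(CI)NCc1cn([C@H]2C[C@H](O)[C@@H](CO)O2)c(=O)[nH]c1=O` gives 107000 nM.
Compound 2 `CC(C)(C)C#Cc1cn([C@@H]2O[C@H](CO)[C@@H](O)[C@@H]2O)c(=O)[nH]c1=O` is reported only as the limit > 200000 nM.
Compound 3 `CS(=O)(=O)Cc1cn([C@H]2C[C@H](O)[C@@H](CO)O2)c(=O)[nH]c1=O` is reported only as the limit > 200000 nM.

Compound 3 thus sits at a limit and not a number, as does compound 2; only compound 1 carries a measured value. Among the measured compounds shown here, the single measured step, an at least 1.8-fold higher number from compound 1 to compound 3 (0.27 log units; that floor lies within the scatter), has its floor inside the scatter. Compound 4 `CC(C)(C)C#Cc1cn([C@H]2C[C@H](O)[C@@H](CO)O2)c(=O)[nH]c1=O` differs from compound 3 by 3,3-dimethylbut-1-yn-1-yl in place of (methylsulfonyl)methyl on an aromatic carbon. For the measured compounds named here, no measured step covers this exact change; compound 2, carrying the same 3,3-dimethylbut-1-yn-1-yl group on its own core, also stands at the limit. Given (the limit of > 200000 nM in this assay, at which 2 of the 3 values shown sit), where compound 3 already sits, no step beyond the scatter is expected for a step that the limit leaves unreadable from compound 3 to compound 4. Compound 4 is estimated at 250000 nM, range 80000 nM to 800000 nM, most likely again only a limit.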

Compound 4, half-maximal inhibitory concentration: > 200000 nM
Compound 4 gave a limit, no number; the forecaster's own chance of this, stated with the estimate: 70%; the middle value lies beyond the limit too.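

In this assay compound 4 is reported only as a limit, > 200000 nM. Among the compounds shown here, the one readable step is an at least 1.8-fold higher number from compound 1 to compound 4 (0.27 log units; that floor lies within the scatter), so 3,3-dimethylbut-1-yn-1-yl on this aromatic carbon, on the core without the ring hydroxy, gives no measured number, and its floor does not separate it from the group of compound 1. The steps to compound 4 from compound 2 and from compound 3 cannot be read, because each pair has both ends at the limit: the limit of > 200000 nM in this assay, at which 3 of the 4 values shown sit.

As far as these compounds go, whether an amine or a carboxylic acid at this aromatic carbon would give a measured number stays open. Any real difference among compound 2, compound 3 and compound 4 also stays open.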